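Indole for furan on two related amide cores

The source may hold more compounds than are shown below. What is called first, only, known or untested is meant among the compounds shown, and "the series" means these compounds.

Four compounds share an amide link between an aromatic ring and a carbonyl carbon, and differ in the group on that carbon and in the core behind it. Compound 1 `CC(C)(C)OC(=O)n1cc(-c2ccc(NC(=O)c3ccco3)cc2)nc1N` carries a furan-2-yl there, and compound 2 `CC(C)(C)OC(=O)n1cc(-c2ccc(NC(=O)c3cc4ccccc4[nH]3)cc2)nc1N` has a 1H-indol-2-yl in its place; the change is 1H-indol-2-yl in place of furan-2-yl on a carbonyl carbon. In an assay on isolated protein for inhibition of sodium channel protein type 4 subunit alpha (Homo sapiens), read by electrophysiology, with a stated time of 4 min (on this read-out higher numbers stand for weaker inhibition and lower numbers for stronger inhibition), compound 1 gives a value that is only a limit of the measurement, > 30000 nM. In this assay compound 2 gives 28000 nM. The step of an at least 1.0-fold lower number from compound 1 to compound 2 (0.02 log units; that floor lies within the scatter) is the result, and it lies within the usual scatter, so the two values cannot be told apart.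

Compound 3 `CNc1nc(-c2cccc(NC(=O)c3ccco3)c2)cn1C(=O)OC(C)(C)C` is built on a different core; how the two cores differ is not broken down here. In this assay compound 3 gives a value that is again only a limit, > 30000 nM. Compound 4 `CNc1nc(-c2cccc(NC(=O)c3cc4ccccc4[nH]3)c2)cn1C(=O)OC(C)(C)C` is the not yet measured partner, and it differs from compound 3 by the same change, (1H-indol-2-yl in place of furan-2-yl on a carbonyl carbon), at the same place.

Because (the limit of > 30000 nM in this assay, at which 2 of the 3 values shown sit), and because an at least 1.0-fold lower number from compound 1 to compound 2 (0.02 log units; that floor lies within the scatter) shows no measurable gain, compound 4 is expected to stay in the same weak region, with a step of about a number no higher from compound 3 to compound 4 (the limit leaves the size open). The estimate for compound 4 in this assay is 30000 nM, most likely between 12000 nM and 60000 nM, with a fair chance that only a limit is reported.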

Compound 4, half-maximal inhibitory concentration: > 30000 nM
Compound 4: only a limit was reported; the forecaster's own chance of this, stated with the estimate: 60%; the middle value lies on the limit itself.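

In this assay compound 4 gives > 30000 nM, which is only a limit of the measurement. Compound 3 is also reported only as a limit, and the step between compound 3 and compound 4 cannot be read. The compounds shown leave open how much 1H-indol-2-yl in place of furan-2-yl on a carbonyl carbon changes inhibition on the core of compound 3.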